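This account rests on a few compounds, and the source may have more. Where it says the series, first, only, none or still open, it means among the compounds named here.

Three compounds sharing one core have gone through an ADME assay on LLC-PK1 cells (Sus scrofa) for permeability (a lower number here means that the compound crosses the layer more slowly, a higher number that the compound crosses the layer faster), so far: compound 1 (`CNc1ccc(-c2nc3ccc(F)nc3o2)cn1`), compound 2 (`CN(C)c1ccc(-c2nc3ccc(F)nc3o2)cn1`) and compound 3 (`Fc1ccc2nc(-c3ccc4[nH]ccc4c3)oc2n1`). Compound 1 reads > 20 10^-6 cm/s as its result, which is a limit and not a number. Compound 2 reads > 20 10^-6 cm/s as its result, again a limit. Compound 3 also has only a limit (> 20 10^-6 cm/s) as its standing, so no exact value anchors it. The whole set is marked by the limit of > 20 10^-6 cm/s in this assay, at which 3 of the 3 values shown sit, and offers no ranking.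

Compound 4 (`Cn1ccc2cc(-c3nc4ccc(F)nc4o3)ccc21`) is derived from compound 3 by one change: methyl in place of hydrogen on an aromatic nitrogen in the side of the molecule that carries the five-membered aromatic ring. Within the data shown here, the only measured step of a related kind, a methyl in place of hydrogen on a nitrogen, is a step that the two limits leave unreadable from compound 1 to compound 2 and gives neither size nor direction. Both of its ends stay at the limit, and that is all it shows. No step beyond the scatter is therefore expected, and the expected change in this assay is a step that the limit leaves unreadable from compound 3 to compound 4 on this reasoning. For compound 4 the estimated value is 25 10^-6 cm/s with 14 10^-6 cm/s to 45 10^-6 cm/s as the expected range, and a further limit is the likeliest report.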

Compound 4, apparent permeability: > 20 10^-6 cm/s
Compound 4 ended at the assay's limit (the forecaster's own chance of this, stated with the estimate: 75%); the middle value lies beyond the limit too.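

Compound 3 and compound 4 both stand at a limit in this assay, so the step between them cannot be read in either size or direction: the limit of > 20 10^-6 cm/s in this assay, at which 4 of the 4 values shown sit. The compounds shown leave open how fast any of them actually crosses the layer, and whether any compound on the shared core would give an exact number rather than a limit.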